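Moving One Fluorine on a Growth Inhibitor

The compounds below may be only part of what the source reports. "The series", "measured", "known", "first", "only" and "open" are said of these compounds alone.

In a functional assay on A549 cells (Homo sapiens) for inhibition, read by CCK-8 assay, with a stated time of 72 h, tested at 2 uM (on this read-out lower numbers stand for less inhibition of growth and higher numbers for more inhibition of growth at the one concentration tested), compound 1 (`Nc1ccccc1NC(=O)/C=C/c1ccc(CSc2cccc(F)c2)cc1`) gives 50.7% at the single concentration tested. In this assay compound 2 (`Nc1ccccc1NC(=O)c1ccc(CSc2cccc(F)c2)cc1`) gives 46.9% on the same read-out. These two values lie within the usual scatter of each other, so the numbers do not separate compound 1 from compound 2.

Compound 3 (`Nc1ccccc1NC(=O)/C=C/c1ccc(CSc2ccc(F)cc2)cc1`) has not been measured yet. It keeps the core of compound 1 but carries 4-fluorophenyl in place of 3-fluorophenyl on a sulfur. The atoms stay the same and are only joined differently. Going by the values given here, no measured pair here shows what a swap of this kind does, so nothing points in either direction, and no change beyond the scatter is expected. The estimate therefore rests on compound 1 at 50.7% as its closest anchor. The estimated step of a number 0.7 percentage points lower from compound 1 to compound 3 (within the scatter) is small and stays within the scatter. For compound 3 the estimated value is 50% with a range from 34% to 66% as the expected bounds.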

Compound 3, percent growth inhibition at one concentration: 51.2%
Compound 3: middle estimate off by 1.2 percentage points, on the low side; measured number inside the range.
By their numbers in this assay, from the lowest: compounds 2, 1 and 3 (each within the scatter of the next).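

In this assay, putting 4-fluorophenyl in place of 3-fluorophenyl on a sulfur gives a number 0.5 percentage points higher from compound 1 to compound 3 (within the scatter), so at this one concentration the two fluorine placements cannot be told apart. The earlier compounds shown here offered no pair that changed this part of the molecule, and this pair now gives a first reading: with the same atoms joined differently and the rest of the core of compound 1 kept, the growth inhibition stays within the usual scatter. Nothing available here speaks to why the two placements read alike.

This single swap moves the fluorine only, so it leaves open whether the fluorine matters at all, and whether a plain phenyl, a chlorine, a methoxy group or an amine on this ring would read the same. As far as these compounds go, it also remains open whether the same swap on the core of compound 2 would behave as it does here, and whether compound 1 and compound 3 would still read alike at other concentrations.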